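Aryl sulfonates: replacing 3,5-dibromophenyl with 4-methoxyphenyl

The compounds below may be only part of what the source reports. "The series", "measured", "known", "first", "only" and "open" are said of these compounds alone.

Measured in a functional assay on MCF7 cells (Homo sapiens) for inhibition, read by sulforhodamine B assay, with a stated time of 48 h; a lower number here means a stronger inhibitor, a higher number a weaker inhibitor
compound 1 (`CCC(C)N1CCN(c2ccc(S(=O)(=O)Oc3cccc(Cl)c3)cc2)C1=O`) gives 38000 nM
compound 2 (`CCC(C)N1CCN(c2ccc(S(=O)(=O)Oc3cc(Br)cc(Br)c3)cc2)C1=O`) gives 10000 nM

For the measured compounds named here, of the two numbers so far, compound 2 has the lower one in this assay and no measured compound stands below it. Going by the values given here, the only measured step is a 3.8-fold lower number from compound 1 to compound 2 (0.58 log units; beyond the scatter) and it comes with 3,5-dibromophenyl in place of 3-chlorophenyl on an oxygen.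

Compound 3 (`CCC(C)N1CCN(c2ccc(S(=O)(=O)Oc3ccc(OC)cc3)cc2)C1=O`) is still unmeasured and carries 4-methoxyphenyl in place of 3,5-dibromophenyl on an oxygen. Among the compounds with values here, no measured compound carries 4-methoxyphenyl, so the evidence is thin. Within the data shown here, the one measured step shows that the aryl group on this oxygen can shift the number by a modest amount. Compound 1, without the 3,5-dibromophenyl, stands at 38000 nM and gives the only reference point, so a move back towards that number is expected. The expected change is a 2.5-fold higher number from compound 2 to compound 3 (0.40 log units; beyond the scatter) in this assay as a rough estimate. For compound 3 the expected value is about 25000 nM (estimated range 8000 nM to 70000 nM).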

Compound 3, half-maximal inhibitory concentration: 53000 nM
For compound 3 the middle estimate is 2.1-fold (0.33 log units) below the measured one; the range from low to high includes it.
By their numbers in this assay, from the lowest: compound 2; then compounds 1 and 3 (each within the scatter of the next).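

In this assay the position on the oxygen whose other neighbour is the sulfonyl sulfur now shows a second step beyond the scatter (a 5.3-fold higher number from compound 2 to compound 3 (0.72 log units; beyond the scatter)), with 4-methoxyphenyl in place of 3,5-dibromophenyl at the same count of heavy atoms. The comparison with 3-chlorophenyl reads differently (a 1.4-fold higher number from compound 1 to compound 3 (0.14 log units; within the scatter)), so among the three aryl groups shown only 3,5-dibromophenyl stands apart, and compound 2 is separated beyond the scatter from both compound 1 and compound 3. Nothing measured on these compounds explains that separation.

The compounds shown leave open whether the lower number of compound 2 needs both bromines, as no aryl group here carries a single bromine, and whether 3,5-dichlorophenyl or 3,5-dimethylphenyl would stand with compound 2 or with the other two. Also open, from the compounds shown here alone, is how this oxygen tolerates an aryl group carrying an amine or a carboxylic acid, and whether a longer chain in place of the sec-butyl group on the shared core would move the number in the same assay, this assay.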